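This account rests on a few compounds, and the source may have more. Where it says the series, first, only, none or still open, it means among the compounds named here.

In a functional assay on a cell-free system (plasma, Homo sapiens), with a stated time of 3 min (on this read-out higher numbers stand for weaker inhibition and lower numbers for stronger inhibition), the measured compounds read as follows:
compound 1 `O=C(NCc1cc(Cl)ccc1-n1cnnn1)[C@@H]1CC=NN1C(=O)[C@H](O)c1ccccc1F` gives 1100 nM
compound 2 `CC1(C[C@@H](O)C(=O)N2N=CC[C@H]2C(=O)NCc2cc(Cl)ccc2-n2cnnn2)CC1` gives 730 nM
compound 3 `CC(C)(C)[C@@H](O)C(=O)N1N=CC[C@H]1C(=O)NCc1cc(Cl)ccc1-n1cnnn1` gives 1400 nM

Compound 3 at 1400 nM lies within the scatter of both other compounds, so these numbers give it no separate rank. The compound still to be measured, compound 4 `CCCC[C@@H](O)C(=O)N1N=CC[C@H]1C(=O)NCc1cc(Cl)ccc1-n1cnnn1`, has butyl in place of tert-butyl on a saturated chain carbon bound to a carbonyl carbon and an oxygen on a saturated carbon. Three measured steps exchange groups at this same place: a 1.5-fold lower number from compound 1 to compound 2 (0.18 log units; within the scatter), a 1.3-fold higher number from compound 1 to compound 3 (0.10 log units; within the scatter) and a 1.9-fold higher number from compound 2 to compound 3 (0.28 log units; within the scatter). All three stay within the scatter, although none of them involves butyl itself. Resting on these steps, no change beyond the scatter is expected in this assay, in either direction. The estimated step is a 1.5-fold lower number from compound 3 to compound 4 (0.17 log units; within the scatter). For compound 4 the estimated value is 950 nM, with an expected range from 430 nM to 2100 nM.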

Compound 4, half-maximal inhibitory concentration: 610 nM
For compound 4 the middle estimate is 1.6-fold (0.19 log units) above the measured one; measured number inside the range.
By their numbers in this assay, from the lowest: compounds 4, 2, 1 and 3 (each within the scatter of the next, the first and the last beyond it).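

In this assay, among these compounds, butyl in place of tert-butyl gives the first step at this place that passes the scatter, a 2.3-fold lower number from compound 3 to compound 4 (0.36 log units; beyond the scatter), even though the two groups have the same atoms, joined differently. The other two new steps stay within the scatter, a 1.2-fold lower number from compound 2 to compound 4 (0.08 log units; within the scatter) and a 1.8-fold lower number from compound 1 to compound 4 (0.26 log units; within the scatter), so butyl cannot be told apart from (1-methylcyclopropyl)methyl or 2-fluorophenyl here. The position therefore does respond to how these carbons are joined, but this rests on a single pair of compounds, and the other pairs show no such separation.

No available evidence accounts for this step. Going by these compounds, whether a longer chain, an amine or a carboxylic acid at this place would move the number beyond the scatter remains open.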